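The source may hold more compounds than are shown below. What is called first, only, known or untested is meant among the compounds shown, and "the series" means these compounds.

Working notes on the series. Two compounds have numbers in an assay on CHO cells for antagonist activity at transient receptor potential cation channel subfamily V member 1 (Homo sapiens), read by FLIPR (a higher number here means a weaker inhibitor, a lower number a stronger inhibitor), so far. Compound 1 `CS(=O)(=O)Nc1ccc(C(C(=O)NCc2ccc(C(F)(F)F)nc2SC2CCCCC2)c2cccc(F)c2)cc1F` gives 48.7 nM in this assay. Among the measured compounds shown here, compound 2 `CC1CCN(c2nc(C(F)(F)F)ccc2CNC(=O)C(c2ccc(F)cc2)c2ccc(NS(C)(=O)=O)c(F)c2)CC1` gives 3.4 nM in this assay, the lowest of the two numbers; the gap to compound 1 lies beyond the scatter, but the two structures differ in more than one place, so the two values show only that compound 2 is the stronger inhibitor of the pair. Compound 3 `CS(=O)(=O)Nc1ccc(C(C(=O)NCc2ccc(C(F)(F)F)nc2SC2CCCCC2)c2ccc(F)cc2)cc1F` has not yet been measured. It differs from compound 2 in one place: cyclohexylsulfanyl in place of 4-methylpiperidin-1-yl on an aromatic carbon. For the measured compounds named here, the cyclohexylsulfanyl group that enters is the one carried by compound 1, the weaker member of the pair, which points toward a higher number for compound 3. The expected step is a 5.9-fold higher number from compound 2 to compound 3 (0.77 log units; beyond the scatter), toward a weaker inhibitor and beyond the scatter. Compound 3 is estimated at 20 nM, within a range of 6 nM to 70 nM.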

Compound 3, inhibition constant: 37.6 nM
The estimate for compound 3 lay 1.9-fold (0.27 log units) below the measured number; the measured number falls inside the stated range.
By their numbers in this assay, from the lowest: compound 2; then compounds 3 and 1 (each within the scatter of the next).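

Read in one place, cyclohexylsulfanyl in place of 4-methylpiperidin-1-yl on the aromatic carbon next to the ring nitrogen gives an 11-fold higher number from compound 2 to compound 3 (1.04 log units; beyond the scatter) in this assay, so this position separates the two groups, which the earlier pair, differing in more than one place, could not show. Moving to 4-fluorophenyl in place of 3-fluorophenyl gives a 1.3-fold lower number from compound 1 to compound 3 (0.11 log units; within the scatter), a step within the scatter, so this change does not register alongside cyclohexylsulfanyl. No measured evidence bears on the reason for the large step at this position.

The compounds shown leave open whether the step follows the atom bound to the aromatic carbon or the methyl on the ring; piperidin-1-yl, morpholin-4-yl or cyclohexylamino at this carbon would separate these. Going by these compounds, whether 3-fluorophenyl and 4-fluorophenyl also stay within the scatter alongside 4-methylpiperidin-1-yl remains open too.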